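Methylcarbamoyl to acetoxymethyl: a step from a limit

The source may report more compounds than this note shows. Statements on the series, on what has been measured and on what is new or still open speak of the compounds shown alone.

In a functional assay on MDA-MB-231 cells (Homo sapiens) for cytotoxicity, read by MTT assay, with a stated time of 72 h (a higher number here means that more compound is needed for the effect, a lower number that less compound is needed), compound 1 (`CCc1cccc2c(O)c(-c3occ(C)c3C(=O)O)ccc12`) gives 0.3 ug/mL. Compound 2 (`CCc1cccc2c(OC)c(-c3occ(C)c3C(=O)NC)ccc12`) gives > 10 ug/mL, which is a limit and not a number. Compound 3 (`CCc1cccc2c(OC)c(-c3occ(C)c3C(=O)On3nnc4ccccc43)ccc12`) gives > 10 ug/mL, also a limit. Compound 2 therefore has no exact value and stands at the limit of > 10 ug/mL in this assay, at which 2 of the 3 values shown sit.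

Compound 4 (`CCc1cccc2c(OC)c(-c3occ(C)c3COC(C)=O)ccc12`) differs from compound 2 in one place: acetoxymethyl in place of methylcarbamoyl on an aromatic carbon. Among the measured compounds shown here, the only measured step between compounds that differ in one place is a step that the two limits leave unreadable from compound 2 to compound 3. It changes the group on the same carbonyl carbon, but it offers no size to carry over, so no clear change is expected. The expected result in this assay is a number no higher from compound 2 to compound 4 (the limit leaves the size open). Compound 4 is estimated at 10 ug/mL, with an expected range of 3 ug/mL to 30 ug/mL.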

Compound 4, concentration for half-maximal effect: 3.5 ug/mL
For compound 4 the middle estimate is 2.9-fold (0.46 log units) above the measured one; the range from low to high includes it.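

Compound 4 gives this position its first readable step: acetoxymethyl in place of methylcarbamoyl brings an at least 2.8-fold lower number from compound 2 to compound 4 (0.45 log units; beyond the scatter). So a change of group on this aromatic carbon can bring the read-out in this assay off the limit, which the step to compound 3, unreadable between two limits, could not show. The full size of the step stays open because compound 2 has no exact value: the limit of > 10 ug/mL in this assay, at which 2 of the 4 values shown sit.

Still open, going by these compounds, is how a hydroxymethyl or an aminomethyl group would read at this place. The compounds shown also do not separate the effect of the ester from that of removing the amide hydrogen.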